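This account rests on a few compounds, and the source may have more. Where it says the series, first, only, none or still open, it means among the compounds named here.

Compound 1 `Nc1ccc(-c2nc3ccc(F)cc3s2)cc1Cl` is the starting point of this account, and in a functional assay on T47D cells (Breast, Homo sapiens) for inhibition (a higher number here means a weaker inhibitor of growth, a lower number a stronger inhibitor of growth), compound 1 gives no result reported, so it stands without a number of its own. Its two companions give the only measured figures. Compound 2 `Cc1cc(-c2nc3cccc(F)c3s2)ccc1N` gives 20 nM in this assay. Among the compounds with values here, compound 3 `Cc1cc(-c2nc3c(F)cccc3s2)ccc1N` gives < 10 nM in this assay, which is a limit of the assay rather than a number, and it is the one value of the three that sits at the limit of < 10 nM in this assay, at which 1 of the 3 values shown sits. Within the data shown here, no step between measured compounds is recorded, so nothing about the size of a single change can be read from them directly.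

The step from compound 1 to compound 4 `Nc1ccc(-c2nc3ccc(F)cc3s2)cc1I` is iodo in place of chloro on an aromatic carbon. The change sits on an aromatic carbon of a six-membered aromatic ring of carbon only, ortho to an amino group and meta to a large group. Since compound 1 carries no number in this assay, the step itself cannot be sized; the expectation is that it falls within the usual scatter rather than beyond it. Compound 4 is therefore estimated to give 15 nM in this assay, with a range from 4 nM to 60 nM.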

Compound 4, concentration for 50% growth inhibition: < 10 nM
Compound 4: no number, only a limit (the forecaster's own chance of this, stated with the estimate: 25%); at least 1.5-fold (0.17 log units) between middle value and limit.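

No step can be read from compound 1 to compound 4 in this assay. Compound 4 gives < 10 nM, which is a limit of the assay and not a number. The compounds shown leave open how much iodo in place of chloro changes growth inhibition.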